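The compounds below may be only part of what the source reports. "The series", "measured", "known", "first", "only" and "open" are said of these compounds alone.

Of the compounds shown here, three sharing one core have been tested in an assay on isolated protein for inhibition of Amine oxidase [flavin-containing] A (Homo sapiens), read by fluorescence and Amplex Red, with a stated time of 30 min; a higher number here means a weaker inhibitor, a lower number a stronger inhibitor. Compound 1 `C(=N/Nc1nc(-c2ccccc2)cs1)\c1ccc(N2CCCC2)cc1` gives 25600 nM, compound 2 `Cc1ccc(-c2csc(N/N=C/c3ccc(N4CCCC4)cc3)n2)cc1` gives 20000 nM, and compound 3 `N#Cc1ccc(-c2csc(N/N=C/c3ccc(N4CCCC4)cc3)n2)cc1` gives 66300 nM, the highest of the three numbers. Compound 4 `Brc1ccc(-c2csc(N/N=C/c3ccc(N4CCCC4)cc3)n2)cc1` carries bromo in place of cyano on an aromatic carbon. Two earlier steps bear on this change, and one does not: a 1.3-fold lower number from compound 1 to compound 2 (0.11 log units; within the scatter) left the cyano group out of play. Because a 2.6-fold higher number from compound 1 to compound 3 (0.41 log units; beyond the scatter) and a 3.3-fold higher number from compound 2 to compound 3 (0.52 log units; beyond the scatter) both came with the cyano group entering and were modest, its departure in favour of bromo is expected to undo most of that rise, landing near where compounds 1 and 2 sit. The expected step is a 2.4-fold lower number from compound 3 to compound 4 (0.37 log units; beyond the scatter). For compound 4 the estimate in this assay is 28000 nM, with a range from 10000 nM to 80000 nM.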

Compound 4, half-maximal inhibitory concentration: 61300 nM
Estimate against measurement, compound 4: 2.2-fold (0.34 log units) below; the range from low to high includes it.
By their numbers in this assay, from the lowest: compounds 2 and 1 (each within the scatter of the next); then compounds 4 and 3 (each within the scatter of the next).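

In this assay, bromo in place of cyano at this position on the aromatic ring brings no recovery (a 1.1-fold lower number from compound 3 to compound 4 (0.03 log units; within the scatter)). The rise seen with cyano is therefore not peculiar to that group, since compound 4 also stands apart from hydrogen (a 2.4-fold higher number from compound 1 to compound 4 (0.38 log units; beyond the scatter)) and methyl (a 3.1-fold higher number from compound 2 to compound 4 (0.49 log units; beyond the scatter)). Nothing available explains why bromo and cyano read alike here. On these data alone, whether an amine or a carboxylic acid at this position would read with compounds 3 and 4 or with compounds 1 and 2 remains open.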